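The source may report more compounds than this note shows. Statements on the series, on what has been measured and on what is new or still open speak of the compounds shown alone.

Compound 1 `CCN1C(=O)CN(Cc2ccc(-c3cccc(CN4CCCCC4)n3)cc2)C1=O` stands highest of the three numbers in an in vitro ADME assay on microsomes from liver (Rattus norvegicus) for metabolic stability, read by LC-MS, using NADPH, tested at 1 uM (a higher number here means that the compound lasts longer, a lower number that the compound disappears faster), where compound 1 gives 0.95 h. Compound 2 `CCN1C(=O)CN(Cc2ccc(-c3ccc(F)c(CN4CCCCC4)n3)cc2)C1=O` gives 0.517 h in this assay, a step of a 1.8-fold lower number from compound 1 to compound 2 (0.26 log units; within the scatter). Compound 3 `O=C1CN(Cc2ccc(-c3ccc(F)c(CN4CCCCC4)n3)cc2)C(=O)N1CC1CCC1` gives 0.0833 h, a step of a 6.2-fold lower number from compound 2 to compound 3 (0.79 log units; beyond the scatter). Compound 4 `CN1C(=O)CN(Cc2ccc(-c3cccc(CN4CCCCC4)n3)cc2)C1=O` is not yet measured; its difference from compound 1 is hydrogen in place of methyl on a saturated chain carbon bound to an amide-type nitrogen in a ring. Within the data shown here, only the step from compound 2 to compound 3 touches the same place, and there a larger group brought a 6.2-fold lower number from compound 2 to compound 3 (0.79 log units; beyond the scatter); the present change goes the other way, to a smaller group, so at most a slight rise is expected, likely not beyond the scatter. For compound 4 the expected step is a 1.3-fold higher number from compound 1 to compound 4 (0.10 log units; within the scatter), giving an estimate of 1.2 h with a range from 0.6 h to 2.4 h.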

Compound 4, half-life: 1.5 h
Estimate against measurement, compound 4: 1.3-fold (0.10 log units) below, and the stated range covers the measured number.
By their numbers in this assay, from the lowest: compound 3; then compounds 2, 1 and 4 (each within the scatter of the next, the first and the last beyond it).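

In this assay, going from ethyl to methyl on a saturated chain carbon bound to an amide-type nitrogen in a ring gives a 1.6-fold higher number from compound 1 to compound 4 (0.20 log units; within the scatter) and does not separate the two chains. Among these compounds, the only other step at this place, to cyclobutyl, gives a 6.2-fold lower number from compound 2 to compound 3 (0.79 log units; beyond the scatter) on the core carrying fluoro, so a change here need not move the number beyond the scatter. Nothing shown bears on what lies behind either step.

The compounds shown leave open how a propyl chain or a methoxyethyl chain would behave at this place. They also leave open whether ethyl to methyl gives a similar step on the core carrying fluoro.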